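Notes on a chloro for fluoro exchange

This account rests on a few compounds, and the source may have more. Where it says the series, first, only, none or still open, it means among the compounds named here.

Values from a functional assay on SK-OV-3 cells (Homo sapiens) for antiproliferative activity, read by MTT assay, with a stated time of 72 h (a higher number here means a weaker inhibitor, a lower number a stronger inhibitor), are as follows
- compound 1 `O=C(CCc1cccc2c1B(O)OC2)Nc1cccc(I)c1` gives 630 nM
- compound 2 `CC(C)c1cccc(NC(=O)CCc2cccc3c2B(O)OC3)c1` gives 510 nM
- compound 3 `O=C(CCc1cccc2c1B(O)OC2)Nc1cccc(-c2cccc(F)c2)c1` gives 480 nM

At 480 nM compound 3 cannot be separated from the other two measured compounds. The next compound is compound 4 `O=C(CCc1cccc2c1B(O)OC2)Nc1cccc(-c2cccc(Cl)c2)c1`, and the change is chloro in place of fluoro on an aromatic carbon. Among the compounds with values here, no measured step makes this exact exchange. The nearest evidence comes from changes of the substituent on the aromatic carbon that carries iodo in compound 1: a 1.2-fold lower number from compound 1 to compound 2 (0.09 log units; within the scatter) and a 1.1-fold lower number from compound 2 to compound 3 (0.03 log units; within the scatter). Going by a 1.3-fold lower number from compound 1 to compound 3 (0.12 log units; within the scatter) as well, no step beyond the scatter is expected in this assay, in either direction. The expected step is a 1.0-fold lower number from compound 3 to compound 4 (0.01 log units; within the scatter). Compound 4 is estimated at 470 nM, with an expected range of 240 nM to 900 nM.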

Compound 4, half-maximal inhibitory concentration: 300 nM
Compound 4: the middle estimate sits 1.6-fold (0.19 log units) above what was measured; measured number inside the range.
By their numbers in this assay, from the lowest: compounds 4, 3, 2 and 1 (each within the scatter of the next, the first and the last beyond it).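

In this assay, 3-chlorophenyl in place of 3-fluorophenyl gives a 1.6-fold lower number from compound 3 to compound 4 (0.20 log units; within the scatter) and so stays inside the scatter, as does 3-chlorophenyl in place of isopropyl, with a 1.7-fold lower number from compound 2 to compound 4 (0.23 log units; within the scatter) on the same scale. New is a 2.1-fold lower number from compound 1 to compound 4 (0.32 log units; beyond the scatter) as the first step in this small set beyond the scatter, though only a modest one, and it runs from iodo to 3-chlorophenyl rather than between the two halogens. Nothing at hand bears on the reason for the size of these steps.

Open, from the compounds shown here alone, is whether bromo, methyl or trifluoromethyl on this aromatic carbon would fall in line with chloro and fluoro. Also open, going by these compounds, is how an amine or a carboxylic acid there would read in this assay on the same core.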